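The source may report more compounds than this note shows. Statements on the series, on what has been measured and on what is new or still open speak of the compounds shown alone.

Compound 1 `CC1(C)[C@H]2CC[C@]1(C)N(Cc1cn(-c3ccccc3F)nn1)C(=O)C2`: 150 nM
Compound 2 `Cc1ccc(-n2cc(CN3C(=O)C[C@@H]4CC[C@@]3(C)C4(C)C)nn2)cc1`: 270 nM
Compound 3 `CC1(C)[C@H]2CC[C@]1(C)N(Cc1cn(-c3cccc(O)c3)nn1)C(=O)C2`: 280 nM

In a functional assay on PANC-1 cells (Homo sapiens) for inhibition, read by MTT assay, with a stated time of 24 h (a higher number here means a weaker inhibitor, a lower number a stronger inhibitor), the three measured compounds cannot be separated. Compound 3 stands level with the other two, as the steps show: a 1.0-fold higher number from compound 2 to compound 3 (0.02 log units; within the scatter), and a 1.9-fold higher number from compound 1 to compound 3 (0.27 log units; within the scatter).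

The next compound is compound 4 `CC1(C)[C@H]2CC[C@]1(C)N(Cc1cn(-c3ccc(Cl)cc3)nn1)C(=O)C2`. The change is 4-chlorophenyl in place of 3-hydroxyphenyl on an aromatic nitrogen: 4-chlorophenyl in place of 3-hydroxyphenyl, on an aromatic nitrogen of a five-membered aromatic ring with 3 nitrogen. The shared core stays as it is.

Among the compounds with values here, the steps that bear on this are the other swaps of the group at that same nitrogen. Besides the two above, there is a 1.8-fold higher number from compound 1 to compound 2 (0.26 log units; within the scatter). Within the data shown here, all three lie within the scatter, but they cover only three groups, and no measured compound carries 4-chlorophenyl. A step beyond the scatter in this assay is therefore not expected, and no firm direction can be given.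

The expected step is a 1.3-fold lower number from compound 3 to compound 4 (0.10 log units; within the scatter).

The estimate for compound 4 is 220 nM, with an expected range from 100 nM to 480 nM.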

Compound 4, half-maximal inhibitory concentration: 440 nM
Compound 4: the middle estimate sits 2.0-fold (0.30 log units) below what was measured, and the stated range covers the measured number.
By their numbers in this assay, from the lowest: compounds 1, 2, 3 and 4 (each within the scatter of the next, the first and the last beyond it).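

In this assay the group on the aromatic nitrogen now gives a step beyond the scatter, with a 2.9-fold higher number from compound 1 to compound 4 (0.47 log units; beyond the scatter) as a modest change, so the choice of group at this position can register in this series. The other two steps do not separate their pairs: a 1.6-fold higher number from compound 3 to compound 4 (0.20 log units; within the scatter) for the exchange of 3-hydroxyphenyl, with its hydrogen-bond donor and acceptor, for 4-chlorophenyl, and a 1.6-fold higher number from compound 2 to compound 4 (0.21 log units; within the scatter) for chloro in place of methyl on an aromatic carbon. No measurement shown explains the one step beyond the scatter.

On these data alone, whether an amine or a carboxylic acid on the phenyl ring would give a larger step at this nitrogen stays open. The compounds shown vary only this group, so the effect of any change to the shared core also remains open.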